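This account rests on a few compounds, and the source may have more. Where it says the series, first, only, none or still open, it means among the compounds named here.

Compound 3 `CN(C(=O)NC(=O)c1cccc(C(F)(F)F)c1)c1nc(C(F)(F)F)c(C(=O)N/N=C/c2ccccc2C(F)(F)F)s1` gives 7.29 ug/mL in a functional assay on BCG823 cells (Homo sapiens) for inhibition, read by MTT assay, with a stated time of 72 h (on this read-out lower numbers stand for stronger inhibition and higher numbers for weaker inhibition), the highest of the three numbers in hand; compound 1 `CN(C(=O)NC(=O)c1ccc(Cl)cc1Cl)c1nc(C(F)(F)F)c(C(=O)N/N=C/c2cccc(C(F)(F)F)c2)s1` gives 6.11 ug/mL and compound 2 `CN(C(=O)NC(=O)c1ccc(Cl)cc1Cl)c1nc(C(F)(F)F)c(C(=O)N/N=C/c2ccc(C(F)(F)F)cc2)s1` gives 3.08 ug/mL in this assay. Compound 4 `CN(C(=O)NC(=O)c1ccc(Cl)cc1Cl)c1nc(C(F)(F)F)c(C(=O)N/N=C/c2ccccc2C(F)(F)F)s1` differs from compound 3 by 2,4-dichlorophenyl in place of 3-(trifluoromethyl)phenyl on a carbonyl carbon. Among the measured compounds shown here, no measured step covers this exchange: the only step in hand, a 2.0-fold lower number from compound 1 to compound 2 (0.30 log units; within the scatter), concerns the other aryl group. Compounds 1 and 2 both carry the 2,4-dichlorophenyl group on the carbonyl carbon; compound 2 lies beyond the scatter from compound 3, compound 1 does not. A small step toward lower numbers, if any, is therefore expected. Compound 4 is estimated at 5 ug/mL (range 2.5 ug/mL to 10 ug/mL) in this assay. This amounts to an expected step of a 1.5-fold lower number from compound 3 to compound 4 (0.16 log units; within the scatter).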

Compound 4, half-maximal inhibitory concentration: 5.73 ug/mL
The estimate for compound 4 lay 1.1-fold (0.06 log units) below the measured number; the range from low to high includes it.
By their numbers in this assay, from the lowest: compounds 2, 4, 1 and 3 (each within the scatter of the next, the first and the last beyond it).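

In this assay, among the compounds shown here, a 1.3-fold lower number from compound 3 to compound 4 (0.10 log units; within the scatter) gives the first reading at the carbonyl carbon, and this exchange of 3-(trifluoromethyl)phenyl for 2,4-dichlorophenyl stays within the scatter. With 2,4-dichlorophenyl held, the 2-(trifluoromethyl)phenyl group gives a 1.9-fold higher number from compound 2 to compound 4 (0.27 log units; within the scatter) and a 1.1-fold lower number from compound 1 to compound 4 (0.03 log units; within the scatter) on the carbon with a double bond to nitrogen, so every step among compounds 1, 2 and 4 lies within the scatter. Nothing in hand bears on a cause for these steps. The compounds shown leave open how an amine or a longer alkyl chain in place of the aryl group on the carbonyl carbon would read.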